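Pyrazolyl sulfonylamidines: thioether aryl swaps and a ring methyl

This account rests on a few compounds, and the source may have more. Where it says the series, first, only, none or still open, it means among the compounds named here.

Measured compounds:
compound 1 `Cc1cc(-c2ccccc2)n(/C(N)=N/S(=O)(=O)c2cc(C)c(Cl)cc2SCc2cccc3ccccc23)n1`: 12000 nM
compound 2 `Cc1cc(-c2ccccc2)n(/C(N)=N/S(=O)(=O)c2cc(C)c(Cl)cc2SCc2cccc(C(F)(F)F)c2)n1`: 40000 nM
compound 3 `Cc1cc(-c2ccccc2)n(/C(N)=N/S(=O)(=O)c2cc(C)c(Cl)cc2SCc2ccccc2)n1`: 10000 nM

In an ADME assay on HaCaT cells (Homo sapiens) for cytotoxicity, read by MTT assay, with a stated time of 72 h (on this read-out lower numbers stand for stronger inhibition and higher numbers for weaker inhibition), compound 1 gives 12000 nM, the second highest of the three numbers. Compound 3 is nearest, with a 1.2-fold lower number from compound 1 to compound 3 (0.08 log units; within the scatter), a difference that stays within the scatter. Among the measured compounds shown here, compound 2 is furthest, with a 3.3-fold higher number from compound 1 to compound 2 (0.52 log units; beyond the scatter); in the same direction, a 4.0-fold lower number from compound 2 to compound 3 (0.60 log units; beyond the scatter) marks the only other step beyond the scatter, and both concern the aryl group on the saturated chain carbon bound to sulfur.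

Compound 4 `Cc1cc(S(=O)(=O)/N=C(\N)n2nccc2-c2ccccc2)c(SCc2cccc3ccccc23)cc1Cl` is not yet measured. It differs from compound 1 in a different place: hydrogen in place of methyl on an aromatic carbon. For the measured compounds named here, none of the measured steps touches the core of compound 1, so no step bears directly on this change; what is known is that a group of one heavy atom leaves from the ring and nothing enters. With no guidance from the series, the expectation is a step no larger than the scatter, no change at the digits printed from compound 1 to compound 4 (within the scatter), in no firm direction. For compound 4 the estimated value in this assay is 12000 nM, with a range from 5000 nM to 30000 nM.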

Compound 4, half-maximal inhibitory concentration: 11000 nM
The estimate for compound 4 lay 1.1-fold (0.04 log units) above the measured number; measured number inside the range.
By their numbers in this assay, from the lowest: compounds 3, 4 and 1 (each within the scatter of the next); then compound 2.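

In this assay, going from 3-methyl-5-phenyl-1H-pyrazol-1-yl to 5-phenyl-1H-pyrazol-1-yl gives a 1.1-fold lower number from compound 1 to compound 4 (0.04 log units; within the scatter), the only step shown that touches the core of compound 1. The earlier steps shown here all concerned the aryl group on the saturated chain carbon bound to sulfur, whereas this one shows that, with naphthalen-1-yl in that place, hydrogen and methyl on this aromatic carbon of the five-membered ring cannot be told apart on this read-out. Nothing available explains this result.

The compounds shown compare only methyl and hydrogen at this carbon, so an ethyl chain, an amine or a carboxylic acid there remains an open case. Also open, as far as these compounds go, is whether the same swap stays within the scatter with phenyl or 3-(trifluoromethyl)phenyl on the chain carbon.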